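Aryl exchange on the core of compound 2

This account rests on a few compounds, and the source may have more. Where it says the series, first, only, none or still open, it means among the compounds named here.

In a functional assay on HL-60 cells (Homo sapiens) for antiproliferative activity, read by MTT assay, with a stated time of 72 h (on this read-out lower numbers stand for stronger inhibition and higher numbers for weaker inhibition), compound 2 `NC1=NC2(CCSCC2)N(OCCCOc2cccc(Cl)c2Cl)C(N)=N1` gives 30 nM, the lowest number among the three measured; compound 3 `NC1=NC2(CCOCC2)N(OCCCOc2ccccc2Cl)C(N)=N1` gives 660 nM and compound 1 `NC1=NC2(CCOCC2)N(OCCCOc2cc(Cl)c(Cl)cc2Cl)C(N)=N1` gives 2360 nM. Compound 2 differs from compound 3 in two places, so only their values are set side by side. For the measured compounds named here, the sole single-point step, a 3.6-fold lower number from compound 1 to compound 3 (0.55 log units; beyond the scatter), sits on the core of compound 1 rather than on that of compound 2. Compound 4 `NC1=NC2(CCSCC2)N(OCCCOc2cccc(Br)c2)C(N)=N1` keeps the core of compound 2 with 3-bromophenyl in place of 2,3-dichlorophenyl on an oxygen on a saturated carbon. Going by the values given here, no measured step bears directly on this exchange; the step just named shows that removing chlorines from the phenyl need not raise the number. A modest rise, at or slightly beyond the scatter, is expected, a 2.7-fold higher number from compound 2 to compound 4 (0.43 log units; beyond the scatter). Compound 4 is expected to give 80 nM in this assay, ranging from 20 nM to 400 nM.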

Compound 4, half-maximal inhibitory concentration: 200 nM
Compound 4: middle estimate off by 2.5-fold (0.40 log units), on the low side; the range from low to high includes it.
By their numbers in this assay, from the lowest: compound 2; then compound 4; then compound 3; then compound 1.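

For the compounds shown here, on the core of compound 2, on an oxygen on a saturated carbon, the exchange of 2,3-dichlorophenyl for 3-bromophenyl gives in this assay a 6.7-fold higher number from compound 2 to compound 4 (0.82 log units; beyond the scatter), the first single-point step on this core. The earlier step, on the core of compound 1, lowered the number as chlorines left, so fewer chlorines on the phenyl do not read the same way across the two cores. Nothing measured gives a reason for this step. The step exchanges the whole aryl group, leaving the parts played by bromine and by chlorine unseparated. Going by these compounds, how 3-chlorophenyl, or a phenyl carrying an amine, would read on this core remains open.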